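Changing the group on the carbonyl of compound 2

The source may hold more compounds than are shown below. What is called first, only, known or untested is meant among the compounds shown, and "the series" means these compounds.

In a functional assay on L1210 cells (Mus musculus) (a higher number here means a weaker inhibitor, a lower number a stronger inhibitor), compound 1 (`O=C(/C=C/c1ccc(Br)cc1)Oc1ccc(/C=C2\CCCCC2=O)cc1`) gives 127000 nM. Compound 2 (`CN(C)CC1CCC/C(=C\c2ccc(OC(=O)/C=C/c3ccc(Br)cc3)cc2)C1=O`) gives 1780 nM, within the scatter of compound 3 (`O=C1CCCC/C1=C\c1ccc(OC(=O)c2ccc(Cl)cc2)cc1`) at 3330 nM. Putting (dimethylamino)methyl in place of hydrogen on a saturated ring carbon produced a large change, a 71-fold lower number from compound 1 to compound 2 (1.85 log units; beyond the scatter). Compound 4 (`COc1ccc(C(=O)Oc2ccc(/C=C3\CCCC(CN(C)C)C3=O)cc2)cc1`) keeps that group but carries 4-methoxyphenyl in place of 2-(4-bromophenyl)ethenyl on a carbonyl carbon. Among the compounds with values here, the one measured step lies at a different place, so it sets no size for this change, and no step at this carbonyl carbon has been measured. No change beyond the scatter is therefore expected in this assay, and the expected step is a 1.1-fold lower number from compound 2 to compound 4 (0.05 log units; within the scatter). For compound 4, the estimated value is 1600 nM, with an expected range of 500 nM to 5000 nM.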

Compound 4, half-maximal inhibitory concentration: 2870 nM
Compound 4: the middle estimate sits 1.8-fold (0.25 log units) below what was measured, and the stated range covers the measured number.
By their numbers in this assay, from the lowest: compounds 2, 4 and 3 (each within the scatter of the next); then compound 1.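

In this assay the change at this carbonyl carbon gives a 1.6-fold higher number from compound 2 to compound 4 (0.21 log units; within the scatter) and stays within the scatter, so the two groups cannot be told apart here. With (dimethylamino)methyl kept, this position tolerates losing the bromine and the double bond outside the aromatic ring, and gaining an oxygen, without a clear shift in the number. No available evidence accounts for this result.

From the compounds shown here alone, whether an amine or a carboxylic acid on this carbonyl carbon would shift the number beyond the scatter remains open. So does whether this swap would behave alike without (dimethylamino)methyl.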